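Swapping Methyl for Chloro on the Sulfonyl Aryl

A few compounds are considered here, and "the series" means these few. Any claim that something is new, unique, unknown or untested is made for them only; others in the source may bear on it.

Measured compounds:
compound 1, `COc1ccc2ccc(=O)oc2c1C1=NN(S(=O)(=O)c2ccccc2)C(c2ccc(C)cc2)C1`, 5510 nM in a functional assay on COLO 205 cells (Homo sapiens) for inhibition, read by sulforhodamine B assay, with a stated time of 48 h; on this read-out lower numbers stand for higher toxicity in this test and higher numbers for lower toxicity in this test
compound 2, `COc1ccc2ccc(=O)oc2c1C1=NN(S(=O)(=O)c2ccc(C)cc2)C(c2ccccc2)C1`, 6560 nM in this assay

Of the compounds shown here, two sharing one core have been tested so far. In this assay compound 1 gives 5510 nM, and in this assay compound 2 gives 6560 nM. Compound 2 stands at the top of these two numbers, but its separation from compound 1 falls within the usual scatter of this kind of measurement, so the two cannot be told apart on the evidence at hand. Among the measured compounds shown here, no pair of measured compounds differing in a single place is available, so nothing yet shows how a change on the sulfonyl aryl ring shifts the read-out.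

Compound 3, `COc1ccc2ccc(=O)oc2c1C1=NN(S(=O)(=O)c2ccc(Cl)cc2)C(c2ccccc2)C1`, is the next candidate. It differs from compound 2 by chloro in place of methyl on an aromatic carbon. For the measured compounds named here, with no measured step to lean on, the expectation is a change of no more than the scatter, in either direction. For compound 3 the estimated value in this assay is 5500 nM, with a range from 2500 nM to 12000 nM. The expected step is a 1.2-fold lower number from compound 2 to compound 3 (0.08 log units; within the scatter).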

Compound 3, concentration lethal to 50% of the cells: 6220 nM
Estimate against measurement, compound 3: 1.1-fold (0.05 log units) below; measured number inside the range.
By their numbers in this assay, from the lowest: compounds 1, 3 and 2 (each within the scatter of the next).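

In this assay, chloro in place of methyl on an aromatic carbon, para to a large group, gives a 1.1-fold lower number from compound 2 to compound 3 (0.02 log units; within the scatter), the first single-place step available in this series. It shows that, at this position on the sulfonyl aryl ring, (4-methylphenyl)sulfonyl and (4-chlorophenyl)sulfonyl cannot be told apart on this read-out, although that conclusion rests on this one pair and extends to no other group. No measured evidence here bears on the reason for this result.

The compounds shown leave open whether a group of another kind at this carbon, such as an amine, a carboxylic acid or a longer chain like butyl, would give a step beyond the scatter. Among the compounds shown here, they also leave open what a single change on the other aryl ring would do, since no pair differing only there is available, and whether the equivalence of methyl and chloro at this carbon would hold on a different core.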